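Working notes on the step from compound 2 to compound 3

A few compounds are considered here, and "the series" means these few. Any claim that something is new, unique, unknown or untested is made for them only; others in the source may bear on it.

Measured compounds:
compound 1 `CN(C(=O)NC(=O)c1ccc(F)c(F)c1)c1nc(C(F)(F)F)c(C(=O)N/N=C/c2ccc(C(F)(F)F)cc2)s1`: 5.1 ug/mL in a functional assay on HeLa cells (Homo sapiens) for inhibition, read by MTT assay, with a stated time of 72 h; on this read-out higher numbers stand for weaker inhibition and lower numbers for stronger inhibition
compound 2 `CN(C(=O)NC(=O)c1ccc(F)c(F)c1)c1nc(C(F)(F)F)c(C(=O)N/N=C/c2ccccc2C(F)(F)F)s1`: 9.24 ug/mL in this assay

Compound 2 carries the highest of the two numbers in this assay; its nearest neighbour is compound 1, and the step of a 1.8-fold higher number from compound 1 to compound 2 (0.26 log units; within the scatter) lies within the scatter, so the two values cannot be told apart.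

Compound 3 `CN(C(=O)NC(=O)c1ccccc1F)c1nc(C(F)(F)F)c(C(=O)N/N=C/c2ccccc2C(F)(F)F)s1` is not yet measured. It differs from compound 2 by 2-fluorophenyl in place of 3,4-difluorophenyl on a carbonyl carbon. Among the compounds with values here, the only measured step concerns the other aryl group on the carbon with a double bond to nitrogen, and that step was within the scatter. Within the data shown here, no measured step touches the carbonyl-side aryl, so nothing in hand speaks for a shift in either direction. The expectation is therefore no step beyond the scatter, a 1.0-fold lower number from compound 2 to compound 3 (0.01 log units; within the scatter). Compound 3 is estimated at 9 ug/mL, with a range from 4 ug/mL to 20 ug/mL.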

Compound 3, half-maximal inhibitory concentration: 10.1 ug/mL
Estimate against measurement, compound 3: 1.1-fold (0.05 log units) below, and the stated range covers the measured number.
By their numbers in this assay, from the lowest: compounds 1, 2 and 3 (each within the scatter of the next).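

In this assay, the carbonyl-side aryl group now has a measured step of its own: 2-fluorophenyl in place of 3,4-difluorophenyl on a carbonyl carbon gives a 1.1-fold higher number from compound 2 to compound 3 (0.04 log units; within the scatter). With the 2-(trifluoromethyl)phenyl group held fixed, these two aryl groups cannot be told apart on this read-out, so this position now shows one change that leaves the value within the scatter, alongside the one on the other aryl group. No measurement in hand bears on the reason for this result.

On these data alone, both groups compared are fluorinated phenyl groups, so it remains open whether a methoxy group, an amine or a longer alkyl chain at this position would give a step beyond the scatter. As far as these compounds go, it is also open whether 2-fluorophenyl behaves the same when paired with the 4-(trifluoromethyl)phenyl group of compound 1.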